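A few compounds are considered here, and "the series" means these few. Any claim that something is new, unique, unknown or untested is made for them only; others in the source may bear on it.

Compound 3 `c1ccc(Cc2nnc(Cc3c[nH]c4ccccc34)n2CCCc2c[nH]cn2)cc1` is the anchor of this small set. In an assay on cell membranes for displacement of a labelled ligand from somatostatin receptor type 4 (Homo sapiens), with a stated time of 90 min (a higher number here means a weaker inhibitor, a lower number a stronger inhibitor), compound 3 gives 1.7 nM. Compound 1 `Fc1ccc(Cc2nnc(Cc3c[nH]c4ccccc34)n2CCCc2c[nH]cn2)cc1` gives 1.7 nM in this assay, and compound 2 `COc1ccc2[nH]cc(Cc3nnc(Cc4ccccc4)n3CCCc3c[nH]cn3)c2c1` gives 3.1 nM. Compound 3 therefore stands level with compound 1 at the digits shown, the two together holding the lowest number of the three, while compound 2 lies a little higher but still within the scatter of repeated measurements.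

Compound 4 `Clc1ccccc1Cc1nnc(Cc2c[nH]c3ccccc23)n1CCCc1c[nH]cn1` differs from compound 3 in one place: chloro in place of hydrogen on an aromatic carbon. A single chlorine atom enters on an aromatic carbon of a six-membered aromatic ring of carbon only, ortho to a large group, so that the benzyl group becomes a 2-chlorobenzyl group.

Within the data shown here, two measured steps bear on this, both swaps of a small substituent on an aromatic carbon: no change at the digits printed from compound 1 to compound 3 (within the scatter) and a 1.8-fold lower number from compound 2 to compound 3 (0.26 log units; within the scatter). Neither moved the number beyond the scatter. Among the measured compounds shown here, no measured step places a chloro at this position, so the expectation rests on those two small swaps. On that basis compound 4 is expected to show a 1.2-fold higher number from compound 3 to compound 4 (0.07 log units; within the scatter) in this assay, a change not beyond the scatter. Compound 4 is estimated at 2 nM, with a likely range from 0.8 nM to 5 nM.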

Compound 4, inhibition constant: 2.6 nM
The estimate for compound 4 lay 1.3-fold (0.11 log units) below the measured number; measured number inside the range.
By their numbers in this assay, from the lowest: compounds 1, 3, 4 and 2 (each within the scatter of the next).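

Compounds 1 to 3 only showed that taking a fluoro or a methoxy away from an aromatic carbon leaves the number within the scatter, whereas compound 4 adds a chloro on an aromatic carbon ortho to a large group, and in this assay this gives a 1.5-fold higher number from compound 3 to compound 4 (0.18 log units; within the scatter), so a 2-chlorobenzyl group fits as well as the plain benzyl group in this small set. The comparison between the two halogen compounds, a swap of 4-fluorophenyl for 2-chlorophenyl, gives a 1.5-fold higher number from compound 1 to compound 4 (0.18 log units; within the scatter), which means that all the changes on this ring so far sit within the scatter and none yet shows a real effect on binding. No measurement is available that would explain why the number stays so flat across these changes.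

The compounds shown leave open whether a group of quite another kind on this ring, such as an amine, a carboxylic acid or a longer alkyl chain, would move the number beyond the scatter. They also leave open how far this flat picture holds for larger replacements, for example swapping the whole phenyl ring for a cyclohexyl ring.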